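The source may report more compounds than this note shows. Statements on the series, on what has been measured and on what is new or still open speak of the compounds shown alone.

Working notes on the series. Compound 3 `CC(CCc1nnn[nH]1)Cc1cccc(OCc2ccc3ccccc3n2)c1` stands second highest of the three numbers in an assay on membranes from lung (Cavia porcellus) for binding affinity to cysteinyl leukotriene receptor (Homo sapiens); on this read-out lower numbers stand for stronger inhibition and higher numbers for weaker inhibition: in this assay compound 3 gives 34 nM, compound 1 `O=C(O)CCCCc1cccc(OCc2ccc3ccccc3n2)c1` gives 100 nM and compound 2 `CCCC(CCc1nnn[nH]1)Cc1cccc(OCc2ccc3ccccc3n2)c1` gives 11 nM. The step to compound 4 `c1cc(CCCCc2nnn[nH]2)cc(OCc2ccc3ccccc3n2)c1` is hydrogen in place of methyl on a saturated chain carbon bound to two saturated chain carbons. Two measured steps are relevant. a 2.9-fold lower number from compound 1 to compound 3 (0.47 log units; beyond the scatter) swaps the whole acid-bearing chain and does not isolate the branch. a 3.1-fold higher number from compound 2 to compound 3 (0.49 log units; beyond the scatter) removes an alkyl branch from the chain and bears directly on it; the same kind of pruning is made here. A modest rise of the number is therefore expected, a 1.8-fold higher number from compound 3 to compound 4 (0.25 log units; within the scatter). Compound 4 is estimated at 60 nM, with a range of 25 nM to 150 nM.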

Compound 4, inhibition constant: 20 nM
The estimate for compound 4 lay 3.0-fold (0.48 log units) above the measured number; the measured number lies below the stated range.
By their numbers in this assay, from the lowest: compounds 2, 4 and 3 (each within the scatter of the next, the first and the last beyond it); then compound 1.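

In this assay, hydrogen in place of methyl on a saturated chain carbon bound to two saturated chain carbons gives a 1.7-fold lower number from compound 3 to compound 4 (0.23 log units; within the scatter), so this branch is not needed for the measured affinity. Hydrogen in place of propyl at the same carbon gives a 1.8-fold higher number from compound 2 to compound 4 (0.26 log units; within the scatter), so neither branched chain separates from the unbranched 3-(1H-tetrazol-5-yl)propyl chain. With the branch absent, 1H-tetrazol-5-yl in place of carboxy can be read alone, and it gives a 5.0-fold lower number from compound 1 to compound 4 (0.70 log units; beyond the scatter).

No evidence on the cause of these steps is available. On these data alone, how a hydroxyl or a phenyl group on this carbon, or a longer unbranched chain, would read remains open.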